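A few compounds are considered here, and "the series" means these few. Any claim that something is new, unique, unknown or untested is made for them only; others in the source may bear on it.

Working notes on the series.

The shared core is carried by compound 1 `c1ccc(C(/N=C2\CCCCCN2)C2CC2)cc1` and by compound 2 `Cc1ccc(C(/N=C2\CCCCCN2)C2CC2)c(C)c1`. In a functional assay on the whole organism (plasma, strain Sprague-Dawley) with Rattus norvegicus as the target, with a stated time of 2 h, at a dose of 50 mg/kg by the oral route (on this read-out higher numbers stand for a stronger effect at the one dose given and lower numbers for a weaker effect), compound 1 gives 41%. In this assay compound 2 gives 43%; the two numbers lie within the usual scatter of each other, so on the numbers shown compound 1 sits on the same footing as compound 2 and nothing separates them.

The next compound, compound 3 `c1ccc(C(/N=C2\CCCCCN2)c2ccco2)cc1`, differs from compound 1 in one place: furan-2-yl in place of cyclopropyl on a saturated chain carbon bound to an aromatic carbon and a double-bonded nitrogen. Going by the values given here, no step of this kind has been measured, so there is no measured pair to read an expectation from; the only ground is that compound 1 and compound 2 both return inhibition in the same band.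

With that in mind, the step from compound 1 to compound 3 in this assay is expected to be small, a number 3 percentage points lower from compound 1 to compound 3 (within the scatter), and not beyond the scatter in either direction. Among the compounds with values here, for compound 3 in this assay the estimate is 38%, with a range from 20% to 58%, the width reflecting that no measured step supports the change.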

Compound 3, a percentage reported as inhibition, in the whole organism at one dose (the size of the read-out at that dose, not a potency): 37%
Beside the measured number, compound 3's estimate is 1 percentage points above it; the measured number falls inside the stated range.
By their numbers in this assay, from the lowest: compounds 3, 1 and 2 (each within the scatter of the next).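

In this assay, furan-2-yl in place of cyclopropyl on a saturated chain carbon bound to an aromatic carbon and a double-bonded nitrogen gives a number 4 percentage points lower from compound 1 to compound 3 (within the scatter) and so supplies a measured pair for this position, which compound 1 and compound 2 did not. On this pair, a five-membered aromatic ring with 1 hetero atom and a three-membered non-aromatic ring of carbon only stand on the same footing at this position, although the entering group has 5 heavy atoms against 3 and 1 hydrogen-bond acceptor where the leaving group has 0. No available evidence bears on why the step has this size.

On these data alone, whether this holds beyond the pair stays open, since a phenyl ring, a longer chain, an amine or a carboxylic acid at this position could give a step either within or beyond the scatter. The read-out also comes from one dose, so it shows the size of the effect of compound 1 and compound 3 at that dose only.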